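A Methyl on the Furan in Adenosine Receptor Ligands

The source may report more compounds than this note shows. Statements on the series, on what has been measured and on what is new or still open speak of the compounds shown alone.

Compound 1 `Nc1nc(-c2ccco2)nc2sc(-c3ccccc3)nc12` and compound 3 `Nc1nc(-c2ccco2)nc2sc(-c3ccco3)nc12` share most of their structure and differ in one part, (furan-2-yl in place of phenyl on an aromatic carbon). In an assay on CHO cells for displacement of a labelled ligand from adenosine receptor A1 (Homo sapiens), read by scintillation counting, with a stated time of 3 h (a higher number here means a weaker inhibitor, a lower number a stronger inhibitor), compound 1 gives 67 nM and compound 3 gives 69 nM; the two numbers are close, and a 1.0-fold higher number from compound 1 to compound 3 (0.01 log units; within the scatter). Compound 2 `Cc1ccc(-c2nc(N)c3nc(-c4ccccc4)sc3n2)o1` carries a small addition relative to compound 1, (methyl in place of hydrogen on an aromatic carbon). In this assay compound 2 gives 28.9 nM, so that a 2.3-fold lower number from compound 1 to compound 2 (0.37 log units; beyond the scatter). Compound 4 `Cc1ccc(-c2nc(N)c3nc(-c4ccco4)sc3n2)o1` has not yet been measured. Relative to compound 3 it bears methyl in place of hydrogen on an aromatic carbon, which is the same change that separates compound 2 from compound 1 and sits at the same place. If that step repeats on the other core, compound 4 is expected to show a 2.3-fold lower number from compound 3 to compound 4 (0.36 log units; beyond the scatter) in this assay, an expectation resting on the single earlier step of a 2.3-fold lower number from compound 1 to compound 2 (0.37 log units; beyond the scatter) and on compound 3 giving 69 nM. One prior example is a thin basis, so the range is kept wide. On that footing compound 4 is estimated at 30 nM, between 14 nM and 65 nM.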

Compound 4, inhibition constant: 45.9 nM
Compound 4: the middle estimate sits 1.5-fold (0.18 log units) below what was measured, within the range that was stated.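

In this assay, the methyl on the furan gives a 1.5-fold lower number from compound 3 to compound 4 (0.18 log units; within the scatter), and this step cannot be told apart from the one seen on the other core: the same change on two cores in this assay, a 2.3-fold lower number (0.37 log units; beyond the scatter) from compound 1 to compound 2 and a 1.5-fold lower number (0.18 log units; within the scatter) from compound 3 to compound 4, 1.5-fold (0.19 log units) apart, within the scatter of two such steps The exchange of phenyl for furan-2-yl, now made with the methyl present, gives a 1.6-fold higher number from compound 2 to compound 4 (0.20 log units; within the scatter), and it also agrees with its earlier counterpart: the same change on two cores in this assay, a 1.0-fold higher number (0.01 log units; within the scatter) from compound 1 to compound 3 and a 1.6-fold higher number (0.20 log units; within the scatter) from compound 2 to compound 4, 1.5-fold (0.19 log units) apart, within the scatter of two such steps Both changes therefore carry from one core to the other as far as these four compounds can tell, but this does not show that the methyl reliably lowers the number, since its step on the second core lies within the scatter and each comparison rests on a single pair of steps.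

As far as these compounds go, a single small group at one place says little about what larger replacements would do, so the effect of an ethyl, a longer chain, an amine or a carboxylic acid in place of the methyl remains open. From the compounds shown here alone, whether the methyl step would repeat with other groups in place of phenyl and furan-2-yl also remains open.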